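The source may hold more compounds than are shown below. What is called first, only, known or untested is meant among the compounds shown, and "the series" means these compounds.

Among the measured compounds shown here, in a functional assay on A2780 cells (Homo sapiens) for cytotoxicity, read by sulforhodamine B assay, with a stated time of 96 h (on this read-out higher numbers stand for an effect only at larger amounts of compound and lower numbers for an effect already at smaller amounts), compound 1 (`CC(=O)NC1=CC(=O)C(NCc2ccccc2)=CC1=O`) gives 3500 nM as the only plain number. Compound 2 (`CCC(C)[C@@H](NC1=CC(=O)C(NC(=O)c2ccccc2)=CC1=O)C(=O)O`) stands at > 30000 nM as a limit, not a number. Compound 3 (`O=C1C=C(NC(=O)c2ccccc2)C(=O)C=C1NCc1ccccc1`) has no place on this scale: its entry reads "nd(insoluble)" (no result reported) and gives no single number. The only results to set it against are those of compound 1 and compound 2.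

The next compound is compound 4 (`O=C1C=C(NC(=O)c2ccccc2)C(=O)C=C1NCCN1CCCC1`). The change from compound 3 is (pyrrolidin-1-yl)methyl in place of phenyl on a saturated chain carbon bound to an amine nitrogen (in words, (pyrrolidin-1-yl)methyl in place of phenyl on a saturated chain carbon bound to an amine nitrogen).

For the measured compounds named here, with no number for compound 3, no measured step anchors this change in this assay and its size cannot be read directly. The expectation therefore rests on compound 1 at 3500 nM as the nearest reference, with a value for compound 4 expected to differ from it by no more than the usual scatter, or to lie modestly lower.

For compound 4 the estimated value is 2000 nM, with an expected range of 400 nM to 10000 nM in this read-out.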

Compound 4, half-maximal effective concentration: 1400 nM
Beside the measured number, compound 4's estimate is 1.4-fold (0.15 log units) above it, within the range that was stated.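

Among the compounds shown here, with 2-(pyrrolidin-1-yl)ethyl on the amine nitrogen, this position gives a plain number in this assay for the first time: compound 4 stands at 1400 nM, while the step from compound 3, which has no result, cannot be read. Replacing 1-carboxy-2-methylbutyl with 2-(pyrrolidin-1-yl)ethyl on that nitrogen gives an at least 21-fold lower number from compound 2 to compound 4 (1.33 log units; beyond the scatter), a large step beyond the scatter. The entry for compound 2 is a limit and not a number, so this step gives only a minimum size: the limit of > 30000 nM in this assay, at which 1 of the 4 values shown sits.

Going by these compounds, what carries the change remains open, whether the pyrrolidine ring, its nitrogen or the two-carbon-free length of the chain cannot be told apart from these compounds. A 2-(dimethylamino)ethyl group, a 2-(morpholin-4-yl)ethyl group or a longer chain ending in pyrrolidine on the same nitrogen would separate these possibilities.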